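Adding a Second Methoxy Group to Compound 2

The source may hold more compounds than are shown below. What is called first, only, known or untested is meant among the compounds shown, and "the series" means these compounds.

Compound 1 `COc1ccc(C(=O)N2CCN(CC(=O)N3CCN(CCCc4c[nH]c5ccccc45)CC3)CC2)cc1`: 148000 nM
Compound 2 `COc1ccc2[nH]cc(CCCN3CCN(C(=O)CN4CCN(C(=O)c5ccccc5)CC4)CC3)c2c1`: > 200000 nM

In an ADME assay on SH-SY5Y cells (Homo sapiens) for cytotoxicity, read by MTT assay, with a stated time of 72 h (a lower number here means a stronger inhibitor, a higher number a weaker inhibitor), compound 2 gives > 200000 nM, which is a limit and not a number. Compound 3 `COc1ccc(C(=O)N2CCN(CC(=O)N3CCN(CCCc4c[nH]c5ccc(OC)cc45)CC3)CC2)cc1` follows from compound 2 by a single change, methoxy in place of hydrogen on an aromatic carbon: phenyl to 4-methoxyphenyl. Among the compounds with values here, no measured step shows what this change does, so no shift beyond the usual scatter is expected in this assay, and no direction is favoured. The expected step is an at least 1.0-fold lower number from compound 2 to compound 3 (0.02 log units; that floor lies within the scatter). For compound 3 the estimated value is 190000 nM, with an expected range of 100000 nM to 350000 nM.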

Compound 3, half-maximal inhibitory concentration: 190000 nM
Compound 3: middle estimate and measured number agree at the digits printed, within the range that was stated.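

In this assay, within the data shown here, the first readable step for methoxy in place of hydrogen on an aromatic carbon is a 1.3-fold higher number from compound 1 to compound 3 (0.11 log units; within the scatter), so at this aromatic carbon of the core the change stays within the scatter. The step for phenyl to 4-methoxyphenyl is an at least 1.0-fold lower number from compound 2 to compound 3 (0.02 log units; that floor lies within the scatter). Its exact size cannot be read, because compound 2 carries a limit and not a number: the limit of > 200000 nM in this assay, at which 1 of the 3 values shown sits.

As far as these compounds go, it remains open whether an amine, a carboxylic acid or a longer chain in place of that methoxy would take the number beyond the scatter.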